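Chloro substituent on the benzoyl ring of the enone series

The source may hold more compounds than are shown below. What is called first, only, known or untested is meant among the compounds shown, and "the series" means these compounds.

Measured so far, all in a functional assay on MDA-MB-231 cells (Homo sapiens) for antiproliferative activity, read by MTT assay, with a stated time of 24 h; a lower number here means a stronger inhibitor, a higher number a weaker inhibitor:
compound 1 `COc1ccc(-c2cc(C(=O)/C=C/c3ccc(Cl)cc3)nc3cc(-c4ccccc4)nn23)cc1OC`: 23700 nM
compound 2 `COc1ccc(C(=O)/C=C/c2cc(-c3ccc(OC)c(OC)c3)n3nc(-c4ccccc4)cc3n2)cc1`: 13900 nM
compound 3 `COc1ccc(-c2cc(/C=C/C(=O)c3ccccc3)nc3cc(-c4ccccc4)nn23)cc1OC`: 11800 nM

Compound 3 has the lowest of the three numbers, but its distance to the others is small: a 1.2-fold lower number from compound 2 to compound 3 (0.07 log units; within the scatter) and a 2.0-fold lower number from compound 1 to compound 3 (0.30 log units; within the scatter) both lie within the scatter, so no ranking among the three can be drawn. The step of a 1.7-fold lower number from compound 1 to compound 2 (0.23 log units; within the scatter) is likewise within the scatter.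

Compound 4 `COc1ccc(-c2cc(/C=C/C(=O)c3ccc(Cl)cc3)nc3cc(-c4ccccc4)nn23)cc1OC` differs from compound 3 by chloro in place of hydrogen on an aromatic carbon. For the measured compounds named here, no measured pair isolates this change in this orientation of the enone. The step from compound 1 to compound 3 removes a chloro from the aryl ring while also reversing the carbonyl and the ethenyl, and it stayed within the scatter; the step from compound 1 to compound 2 replaces a chloro-bearing arm with a methoxy-bearing one of the other orientation, also within the scatter. Nothing in these numbers suggests that a single chloro moves the value beyond the scatter in either direction.

Compound 4 is therefore expected to sit close to compound 3, with a 1.0-fold higher number from compound 3 to compound 4 (0.01 log units; within the scatter) expected to be no more than the scatter; the estimate for compound 4 is 12000 nM, with a range from 5000 nM to 30000 nM.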

Compound 4, half-maximal inhibitory concentration: 17100 nM
Beside the measured number, compound 4's estimate is 1.4-fold (0.15 log units) below it; the range from low to high includes it.
By their numbers in this assay, from the lowest: compounds 3, 2, 4 and 1 (each within the scatter of the next).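

In this assay, chloro in place of hydrogen is now isolated on the aromatic carbon para to a large group, with the enone orientation held fixed: a 1.4-fold higher number from compound 3 to compound 4 (0.16 log units; within the scatter) shows that this single change does not separate from hydrogen. Chloro in place of methoxy at the same place gives a 1.2-fold higher number from compound 2 to compound 4 (0.09 log units; within the scatter), so the three groups tested here, hydrogen, chloro and methoxy, cannot be told apart in this assay, while a 1.4-fold lower number from compound 1 to compound 4 (0.14 log units; within the scatter) gives the first reading of the enone reversal alone, with the chloro-bearing aryl ring kept, and that reversal also does not separate. No supporting data bear on these small steps, so nothing can be said about their origin.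

Still open, as far as these compounds go, is whether a primary amine, a carboxylic acid or a longer alkoxy chain at this place would move the number beyond the scatter, a question that hydrogen, chloro and methoxy do not answer. Also open, from the compounds shown here alone, is whether reversing the enone would read the same with hydrogen or methoxy on the aryl ring as it does with chloro.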